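This account rests on a few compounds, and the source may have more. Where it says the series, first, only, none or still open, it means among the compounds named here.

In a functional assay on HUVEC cells (Homo sapiens), read by scintillation counting and thymidine incorporation, with a stated time of 24 h (on this read-out lower numbers stand for stronger inhibition and higher numbers for weaker inhibition), compound 1 `CCC(C)n1ncn(-c2ccc(N3CCN(c4ccc(OC[C@@H]5CO[C@@](Cn6nc(C)nc6C)(c6ccc(Cl)cc6Cl)O5)cc4)CC3)cc2)c1=O` gives 221 nM and compound 2 `CCC(C)n1ncn(-c2ccc(N3CCN(c4ccc(OC[C@@H]5CO[C@@](Cn6cc(C)nc6C)(c6ccc(Cl)cc6Cl)O5)cc4)CC3)cc2)c1=O` gives 492 nM. Compound 2 therefore has the higher of the two numbers, which makes it the weaker inhibitor of this pair. Compound 3 `CCC(C)n1ncn(-c2ccc(N3CCN(c4ccc(OC[C@@H]5CO[C@@](Cn6cc(C(F)(F)F)nc6C)(c6ccc(Cl)cc6Cl)O5)cc4)CC3)cc2)c1=O`, not yet measured, differs from compound 2 in one group, with trifluoromethyl in place of methyl on an aromatic carbon. This turns 2,4-dimethyl-1H-imidazol-1-yl into 2-methyl-4-(trifluoromethyl)-1H-imidazol-1-yl. Going by the values given here, only one measured step offers any guide. Putting 2,4-dimethyl-1H-imidazol-1-yl in place of 3,5-dimethyl-1H-1,2,4-triazol-1-yl gave a 2.2-fold higher number from compound 1 to compound 2 (0.35 log units; beyond the scatter), a modest step just beyond the usual scatter. That step exchanged the whole group rather than a single methyl, so it suggests a likely scale but not a direction. Among the compounds with values here, no measured pair here shows what trifluoromethyl in place of methyl does. A small change with no firm direction is therefore expected, and the estimated step is a 1.1-fold lower number from compound 2 to compound 3 (0.04 log units; within the scatter). For compound 3 the estimated value is 450 nM, with an expected range from 180 nM to 1150 nM.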

Compound 3, half-maximal inhibitory concentration: 441 nM
Compound 3: the middle estimate sits 1.0-fold (0.01 log units) above what was measured; the measured number falls inside the stated range.
By their numbers in this assay, from the lowest: compounds 1, 3 and 2 (each within the scatter of the next, the first and the last beyond it).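

Going by these compounds alone, this is the first look at this ring carbon on its own. In this assay, replacing methyl, with 1 heavy atom, by trifluoromethyl, with 4 heavy atoms, on this carbon of the five-membered aromatic ring gives a 1.1-fold lower number from compound 2 to compound 3 (0.05 log units; within the scatter), so this larger group leaves the number indistinguishable from that of the methyl compound. Exchanging the whole 3,5-dimethyl-1H-1,2,4-triazol-1-yl group for 2-methyl-4-(trifluoromethyl)-1H-imidazol-1-yl gives a 2.0-fold higher number from compound 1 to compound 3 (0.30 log units; within the scatter), so this pair also cannot be separated, unlike the pair that carries the 2,4-dimethyl-1H-imidazol-1-yl group. Nothing available explains why the read-out responds in this way to either exchange.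

On these data alone, with only methyl and trifluoromethyl to compare here, it remains open how a carboxylic acid, an amine or a longer chain such as propyl would behave on this ring carbon. Within the data shown here, the role of the other methyl group on the ring also remains open, as no compound here changes it while keeping the rest of the structure the same.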